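Swapping the Aryl Group on the Aromatic Nitrogen

This account rests on a few compounds, and the source may have more. Where it says the series, first, only, none or still open, it means among the compounds named here.

Compound 3 `COc1ccc(-n2nc(C(=O)Nc3ccc(Oc4ccnc5cc(OCCCN6CCC(C)CC6)c(OC)cc45)c(F)c3)c(C)cc2=O)cc1` stands second highest of the three values in a functional assay on MKN-45 cells (Homo sapiens) for inhibition, read by MTT assay, with a stated time of 72 h (a lower number here means a stronger inhibitor, a higher number a weaker inhibitor), where compound 3 gives 400 nM. Compound 1 `COc1cc2c(Oc3ccc(NC(=O)c4nn(-c5ccccc5C)c(=O)cc4C)cc3F)ccnc2cc1OCCCN1CCC(C)CC1` gives 1290 nM, and compound 2 `COc1cc2c(Oc3ccc(NC(=O)c4nn(-c5cccc(F)c5)c(=O)cc4C)cc3F)ccnc2cc1OCCCN1CCC(C)CC1` gives 140 nM. The steps among them are a 9.2-fold lower number from compound 1 to compound 2 (0.96 log units; beyond the scatter), a 3.2-fold lower number from compound 1 to compound 3 (0.51 log units; beyond the scatter) and a 2.9-fold higher number from compound 2 to compound 3 (0.46 log units; beyond the scatter). Compound 4 `COc1cc2c(Oc3ccc(NC(=O)c4nn(-c5ccc(Cl)cc5Cl)c(=O)cc4C)cc3F)ccnc2cc1OCCCN1CCC(C)CC1` varies the same position: 2,4-dichlorophenyl in place of 4-methoxyphenyl on an aromatic nitrogen. All three measured steps bear on this change, each modest in size; compound 1, carrying 2-methylphenyl, gave the highest number, while compound 2, carrying 3-fluorophenyl, gave the lowest. A step of a 1.3-fold higher number from compound 3 to compound 4 (0.10 log units; within the scatter) is therefore expected, small enough that it may stay within the scatter. The estimate for compound 4 is 500 nM, with a range from 150 nM to 1700 nM.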

Compound 4, half-maximal inhibitory concentration: 120 nM
For compound 4 the middle estimate is 4.2-fold (0.62 log units) above the measured one, and the stated range ends above it.
By their numbers in this assay, from the lowest: compounds 4 and 2 (each within the scatter of the next); then compound 3; then compound 1.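

Replacing 4-methoxyphenyl with 2,4-dichlorophenyl on the aromatic nitrogen gives a 3.3-fold lower number from compound 3 to compound 4 (0.52 log units; beyond the scatter), so the methoxy-bearing ring is not the better of these two groups in this assay. Among the compounds shown here, replacing 2-methylphenyl with 2,4-dichlorophenyl gives an 11-fold lower number from compound 1 to compound 4 (1.03 log units; beyond the scatter), the only step at this position printed as large. Against 3-fluorophenyl, the change gives a 1.2-fold lower number from compound 2 to compound 4 (0.07 log units; within the scatter), so these two aryl groups cannot be told apart here.

Nothing available explains these differences. As far as these compounds go, whether a pyridyl ring, or a phenyl ring carrying an amine or a carboxylic acid, would hold this level remains open.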